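A New Aryl Group on the Double-Bonded Carbon

The source may report more compounds than this note shows. Statements on the series, on what has been measured and on what is new or still open speak of the compounds shown alone.

Compound 1 `COc1cc2c(Oc3ccc(NC(=O)N/N=C/c4ccc(F)cc4Cl)cc3F)ccnc2cc1OCCCN1CCCCC1`: 790 nM
Compound 2 `COc1cc2c(Oc3ccc(NC(=O)N/N=C/c4ccc(Cl)cc4Cl)cc3F)ccnc2cc1OCCCN1CCCCC1`: 750 nM

In a functional assay on MDA-MB-231 cells (Homo sapiens) for cytotoxicity, read by MTT assay, with a stated time of 72 h (a higher number here means a weaker inhibitor, a lower number a stronger inhibitor), compound 2 gives 750 nM, the lowest of the two numbers shown. Its nearest neighbour is compound 1, which gives 790 nM, and the two lie within the scatter of each other, so nothing separates them.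

Compound 3 `COc1cc2c(Oc3ccc(NC(=O)N/N=C/c4ccc(OC(F)(F)F)cc4)cc3F)ccnc2cc1OCCCN1CCCCC1` differs from compound 2 by 4-(trifluoromethoxy)phenyl in place of 2,4-dichlorophenyl on a carbon with a double bond to nitrogen. For the measured compounds named here, only one measured step exists, a 1.1-fold lower number from compound 1 to compound 2 (0.02 log units; within the scatter), and it exchanges one halogen for another on the same ring; it bears only loosely on a change that replaces the whole ring with its substituents, but it does show that altering that ring left the number within the scatter. Going by the values given here, no measured compound carries a trifluoromethoxy-bearing ring. One therefore expects no step beyond the scatter, a 1.1-fold higher number from compound 2 to compound 3 (0.03 log units; within the scatter). For compound 3 the estimate in this assay is 800 nM, with a range from 300 nM to 2200 nM.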

Compound 3, half-maximal inhibitory concentration: 820 nM
Compound 3: middle estimate off by 1.0-fold (0.01 log units), on the low side; low and high end bracket the measured number.
By their numbers in this assay, from the lowest: compounds 2, 1 and 3 (each within the scatter of the next).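

Exchanging the whole aryl group on the carbon with a double bond to nitrogen, and not only one halogen on it, still leaves the number in this assay within the scatter (a 1.1-fold higher number from compound 2 to compound 3 (0.04 log units; within the scatter); a 1.0-fold higher number from compound 1 to compound 3 (0.02 log units; within the scatter)). This position therefore takes 4-(trifluoromethoxy)phenyl, the group with more heavy atoms and with a hydrogen-bond acceptor where 2,4-dichlorophenyl has none, without a step beyond the scatter in these three compounds. No evidence is available on why the number stays level here.

The compounds shown leave open whether any group at this position can move the number beyond the scatter at all. A phenyl ring carrying a dimethylamino group or a carboxylic acid, or a pyridine ring in place of the phenyl ring, would test that.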